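Trimming the Aryl Group of Compound 2 to an Amino

This account rests on a few compounds, and the source may have more. Where it says the series, first, only, none or still open, it means among the compounds named here.

Measured compounds:
compound 1 `COc1cc(NC(C)CCCNC(=O)NNC(=O)N(CCO)CCO)c2ncccc2c1` — > 250000 nM, a limit of the assay
compound 2 `COc1cc(NC(C)CCCNC(=O)Nc2ccc(Cl)c(C(F)(F)F)c2)c2ncccc2c1` — 3400 nM
compound 3 `COc1ccc(/C(=N/NC(=O)NNC(=O)NCCCC(C)Nc2cc(OC)cc3cccnc23)c2ccccc2)cc1` — 12000 nM

In a functional assay on MOLT-4 cells (Homo sapiens) for inhibition, read by MTT assay, with a stated time of 4 days (on this read-out lower numbers stand for stronger inhibition and higher numbers for weaker inhibition), compound 2 gives 3400 nM, the lowest of the two numbers recorded. Compound 3 gives 12000 nM, a higher number, and the gap between the two lies beyond the scatter. Compound 1 reaches only a limit of the assay, > 250000 nM; that limit is the limit of > 250000 nM in this assay, at which 1 of the 3 values shown sits.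

The unmeasured compound 4 `COc1cc(NC(C)CCCNC(=O)NN)c2ncccc2c1` differs from compound 2 in one place: amino in place of 4-chloro-3-(trifluoromethyl)phenyl on an amide-type nitrogen. Within the data shown here, the only measured step that bears on this change is an at least 73-fold lower number from compound 1 to compound 2 (1.86 log units; beyond the scatter), where a polar substituent on the same amide-type nitrogen was replaced by the 4-chloro-3-(trifluoromethyl)phenyl group and the number fell sharply. Compound 4 goes in the opposite direction, removing that aryl group for a small polar amino, so a large rise in the number of compound 4 in this assay is expected, with a real chance that only a limit is returned. Compound 4 is therefore estimated at 80000 nM, between 15000 nM and 250000 nM, a step of a 24-fold higher number from compound 2 to compound 4 (1.37 log units; beyond the scatter) expected from compound 2.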

Compound 4, half-maximal inhibitory concentration: >= 250000 nM
Compound 4: a limit, no number (the forecaster's own chance of this, stated with the estimate: 40%); at least 3.1-fold (0.49 log units) between middle value and limit.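

In this assay, the change shows an at least 73-fold higher number from compound 2 to compound 4 (1.86 log units; beyond the scatter), so the amino on this amide-type nitrogen, like the group carried there by compound 1, leaves none of the inhibition that compound 2 shows with its 4-chloro-3-(trifluoromethyl)phenyl. Compound 4 stops at a limit of the assay, not a number: the limit of >= 250000 nM in this assay, at which 1 of the 4 values shown sits. Compound 1 also stands at a limit, and the step between compound 1 and compound 4 cannot be read.

The compounds shown leave open which part of the 4-chloro-3-(trifluoromethyl)phenyl carries this step, a question that a plain phenyl, or a phenyl bearing only the chlorine or only the trifluoromethyl, on the same nitrogen would address. They also leave open whether compound 1 and compound 4 differ at all in this assay.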